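The source may report more compounds than this note shows. Statements on the series, on what has been measured and on what is new or still open speak of the compounds shown alone.

Compound 2 `Cc1ccc(O)c(/C=N/NC(=S)N/N=C2\C(=O)Nc3ccc(C)cc32)c1` differs from compound 1 `Cc1ccc(O)c(/C=N/NC(=S)N/N=C2\C(=O)Nc3ccc(Br)cc32)c1` by methyl in place of bromo on an aromatic carbon. In a functional assay on HeLa cells (Homo sapiens) for inhibition, read by MTT assay (on this read-out higher numbers stand for weaker inhibition and lower numbers for stronger inhibition), compound 2 gives only a limit, > 50000 nM. In this assay compound 1 also gives only a limit, > 50000 nM. The step that the two limits leave unreadable from compound 1 to compound 2 is therefore unreadable; both values are the limit of > 50000 nM in this assay, at which 2 of the 3 values shown sit. Compound 3 `COc1ccc(/C=N/NC(=S)N/N=C2\C(=O)Nc3ccc(Br)cc32)cc1O`, with 3-hydroxy-4-methoxyphenyl in place of 2-hydroxy-5-methylphenyl on the carbon with a double bond to nitrogen, gives 2220 nM in this assay, so the step of an at least 22-fold lower number from compound 1 to compound 3 (1.35 log units; beyond the scatter) shows that replacing this aryl group can bring the number down from the limit.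

Compound 4 `Cc1ccc2c(c1)/C(=N/NC(=S)N/N=C/c1c(F)cccc1Cl)C(=O)N2` is not yet measured in this assay. Its change from compound 2 is 2-chloro-6-fluorophenyl in place of 2-hydroxy-5-methylphenyl on a carbon with a double bond to nitrogen. Within the data shown here, the only measured step that bears on it is an at least 22-fold lower number from compound 1 to compound 3 (1.35 log units; beyond the scatter), where the same group leaves; here the entering group has no hydrogen-bond donor or acceptor, so the transfer is uncertain. A step downward, smaller than that one, is expected as an at least 3.3-fold lower number from compound 2 to compound 4 (0.52 log units; beyond the scatter). Compound 4 is estimated at 15000 nM, between 3000 nM and 50000 nM.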

Compound 4, half-maximal inhibitory concentration: 1510 nM
Estimate against measurement, compound 4: 9.9-fold (1.00 log units) above, outside the stated range (below it).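

In this assay compound 2 gives > 50000 nM, which is a limit and not a number, so the step from it is a bound only: the limit of > 50000 nM in this assay, at which 2 of the 4 values shown sit. Among these compounds, on the carbon with a double bond to nitrogen, 2-chloro-6-fluorophenyl in place of 2-hydroxy-5-methylphenyl gives an at least 33-fold lower number from compound 2 to compound 4 (1.51 log units; beyond the scatter), so losing this aryl group lowers the number on the core of compound 2 as well, whereas the earlier compounds showed such a drop only on the core of compound 1. The entering group has 0 hydrogen-bond donors and 0 hydrogen-bond acceptors, so a hydroxy group on this aryl ring is not required for a measurable value.

On these data alone, it remains open whether the chloro or the fluoro substituent carries the step. As far as these compounds go, it is equally open whether an aromatic ring is needed at this carbon at all, which a pyridine ring, a phenyl ring bearing an amine or a plain butyl chain would test.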